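The compounds below may be only part of what the source reports. "The series", "measured", "known", "first", "only" and "open" are said of these compounds alone.

Of the compounds shown here, two have so far been measured in a functional assay on SK-MEL-28 cells (Homo sapiens) for cytotoxicity, read by MTT assay; a higher number here means a weaker inhibitor, a lower number a stronger inhibitor. Compound 1 `O=S(=O)(NCCCNc1nccc(-c2c(-c3cccc(F)c3)nc3sccn23)n1)c1ccc(Br)cc1` gives 9400 nM in this assay, and compound 2 `O=C(NCCNc1nccc(-c2c(-c3cccc(F)c3)nc3sccn23)n1)c1ccc(Cl)cc1` gives 8160 nM. Compound 2 holds the lowest of the two numbers, but the step of a 1.2-fold lower number from compound 1 to compound 2 (0.06 log units; within the scatter) lies within the scatter, so the two compounds cannot be separated on these data. Compound 3 `O=S(=O)(NCCCNc1nccc(-c2c(-c3cccc(F)c3)nc3sccn23)n1)c1ccccc1` differs from compound 2 by ((phenylsulfonyl)amino)methyl in place of ((4-chlorophenyl)carbonyl)amino on a saturated chain carbon, two bonds along the chain from a nitrogen on an aromatic ring. Among the compounds with values here, the one measured step bears directly on this change, since it exchanged closely related groups at the same place and stayed within the scatter; compound 3 in fact differs from compound 1 only by lacking bromine. No step beyond the scatter is therefore expected in this assay. Compound 3 is expected to give about 9500 nM, with a range from 4000 nM to 24000 nM. This estimate corresponds to an expected step of a 1.2-fold higher number from compound 2 to compound 3 (0.07 log units; within the scatter), within the scatter.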

Compound 3, half-maximal inhibitory concentration: 6850 nM
Compound 3: the middle estimate sits 1.4-fold (0.14 log units) above what was measured, and the stated range covers the measured number.
By their numbers in this assay, from the lowest: compounds 3, 2 and 1 (each within the scatter of the next).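

In this assay, hydrogen in place of bromo on an aromatic carbon gives a 1.4-fold lower number from compound 1 to compound 3 (0.14 log units; within the scatter) and so, for this pair, the bromine makes no difference that can be told from the scatter. Replacing ((4-chlorophenyl)carbonyl)amino with ((phenylsulfonyl)amino)methyl on the saturated chain gives a 1.2-fold lower number from compound 2 to compound 3 (0.08 log units; within the scatter) and this second exchange, which removes the chlorine and swaps the carbonyl for a sulfonyl, also cannot be told from the scatter. Nothing measured here offers an explanation for these numbers.

All three compounds therefore remain unranked in this assay. Still open, going by these compounds, is whether a clear step would appear with an amine or a carboxylic acid on the aromatic ring in place of that hydrogen, or with a longer chain.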